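A few compounds are considered here, and "the series" means these few. Any claim that something is new, unique, unknown or untested is made for them only; others in the source may bear on it.

In a functional assay on A549 cells (Homo sapiens) for antiproliferative activity, read by MTT assay, with a stated time of 72 h (on this read-out lower numbers stand for stronger inhibition and higher numbers for weaker inhibition), two compounds have been measured so far. Compound 1 `C/C=C/C(=O)Nc1cc2c(N3CCCc4ccccc43)ncnc2cc1OC` gives 8190 nM. Compound 2 `COc1cc2ncnc(N3CCc4ccccc43)c2cc1NC(=O)/C=C/CN1CCN(C)CC1` gives 5360 nM, the lowest of the two numbers, with compound 1 the nearest at a gap that lies within the scatter, so the two cannot be ordered. Compound 3 `COc1cc2ncnc(N3CCCc4ccccc43)c2cc1NC(=O)/C=C/CN1CCN(C)CC1` has not yet been measured; it differs from compound 2 by 1,2,3,4-tetrahydroquinolin-1-yl in place of 2,3-dihydro-1H-indol-1-yl on an aromatic carbon. No step between measured compounds that changes one place alone is available, and compound 1 and compound 2 differ from each other at two places, so the weight of this exchange on its own cannot be read from the numbers shown. The step from compound 2 to compound 3 is therefore expected to stay within the scatter, in either direction, as a 1.1-fold higher number from compound 2 to compound 3 (0.05 log units; within the scatter). Compound 3 is estimated at 6000 nM in this assay, with a range from 2000 nM to 18000 nM.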

Compound 3, half-maximal inhibitory concentration: 7830 nM
The estimate for compound 3 lay 1.3-fold (0.12 log units) below the measured number; the measured number falls inside the stated range.
By their numbers in this assay, from the lowest: compounds 2, 3 and 1 (each within the scatter of the next).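

In this assay, 1,2,3,4-tetrahydroquinolin-1-yl in place of 2,3-dihydro-1H-indol-1-yl on this aromatic carbon gives a 1.5-fold higher number from compound 2 to compound 3 (0.16 log units; within the scatter), so the weight of this exchange alone can now be read, and it does not separate the two compounds. Among these compounds, compound 3 also isolates the chain for the first time: 4-methylpiperazin-1-yl in place of hydrogen on the saturated chain carbon bound to a double-bonded chain carbon gives a 1.0-fold lower number from compound 1 to compound 3 (0.02 log units; within the scatter), again with no order between the pair. Nothing measured here offers an explanation for either result. The compounds shown leave open whether dimethylamino in place of 4-methylpiperazin-1-yl, or an anilino group in place of 1,2,3,4-tetrahydroquinolin-1-yl, would move the number beyond the scatter. On these data alone, each exchange has also been read only once, so whether it holds with a different group at the other place remains open.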